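From an Octyl Chain to a Phenyl Ring

This account rests on a few compounds, and the source may have more. Where it says the series, first, only, none or still open, it means among the compounds named here.

Three compounds share one core and differ only in a saturated chain: compound 1 `CCCCc1ccc(-c2c(C)[nH]c(=O)n2C2CCCCC2)cc1`, compound 2 `CCCc1ccc(-c2c(C)[nH]c(=O)n2C2CCCCC2)cc1` and compound 3 `CCCCCCCCc1ccc(-c2c(C)[nH]c(=O)n2C2CCCCC2)cc1`. In a functional assay on brain (Rattus norvegicus, strain Wistar) for inhibition (on this read-out lower numbers stand for stronger inhibition and higher numbers for weaker inhibition), compound 1 gives 27100 nM, compound 2 gives 13900 nM and compound 3 gives 10300 nM. Compound 3 sits at the low end of these numbers, but its nearest neighbour is close: a 1.3-fold lower number from compound 2 to compound 3 (0.13 log units; within the scatter). Its furthest neighbour lies clearly apart: a 2.6-fold lower number from compound 1 to compound 3 (0.42 log units; beyond the scatter).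

Compound 4 `Cc1[nH]c(=O)n(C2CCCCC2)c1-c1ccc(-c2ccccc2)cc1` gives up the chain altogether. The change is phenyl in place of octyl on an aromatic carbon, para to a large group. Only the chain changes bear on this, and they are small. Besides the two steps above, there is a 1.9-fold lower number from compound 1 to compound 2 (0.29 log units; within the scatter). None of them puts a ring at this place, so they offer only a rough guide, and the range must stay wide.

With no large step among these compounds, no shift beyond the scatter is expected in this assay. The estimated change is a 1.5-fold higher number from compound 3 to compound 4 (0.16 log units; within the scatter). Compound 4 is expected at about 15000 nM, within an estimated range of 5000 nM to 45000 nM.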

Compound 4, half-maximal inhibitory concentration: 10900 nM
The estimate for compound 4 lay 1.4-fold (0.14 log units) above the measured number; the range from low to high includes it.
By their numbers in this assay, from the lowest: compounds 3, 4, 2 and 1 (each within the scatter of the next, the first and the last beyond it).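

The earlier compounds shown here varied only a saturated chain, so they could not show whether this aromatic carbon accepts a ring, and compound 4 shows that in this assay it can: replacing octyl with phenyl gives a 1.1-fold higher number from compound 3 to compound 4 (0.02 log units; within the scatter), so a six-membered aromatic ring of carbon only does as well here as the longest chain. The same holds against the propyl chain, with a 1.3-fold lower number from compound 2 to compound 4 (0.11 log units; within the scatter), whereas the butyl chain is the only one that stands clearly apart from the ring, with a 2.5-fold lower number from compound 1 to compound 4 (0.40 log units; beyond the scatter), and so the result does not sort simply into rings and chains. Nothing available explains why a flat ring and a long flexible chain give such similar numbers.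

On these data alone, what an amine or a carboxylic acid would do on this aromatic carbon remains open, as does the effect of a much shorter group such as methyl. It is also unknown whether a chlorine atom or a methoxy group on the new phenyl ring would move the number beyond the scatter.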